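A few compounds are considered here, and "the series" means these few. Any claim that something is new, unique, unknown or untested is made for them only; others in the source may bear on it.

Measured so far in a functional assay on the whole organism (strain albino) for inhibition, with Rattus norvegicus as the target, read by paw edema, with stated times of 1 h and 3 h, at a dose of 20 mmol/kg by the intraperitoneal route; on this read-out lower numbers stand for a weaker effect and higher numbers for a stronger effect at the one dose given:
compound 1, `N#CC1=C(NCC(=O)N2CCCC2)N(c2ccccc2)C(=O)N2CCCCC(N3CCCC3)C12`, gives 56%.
compound 2, `N#CC1=C(/N=C/Nc2ccccc2)N(c2ccccc2)C(=O)N2CCCCC(N3CCCC3)C12`, gives 79.3%.
compound 3, `N#CC1=C(/N=C/c2ccc([N+](=O)[O-])cc2)N(c2ccccc2)C(=O)N2CCCCC(N3CCCC3)C12`, gives 91.7%.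

Compound 3 stands highest of the three, with a number 12.4 percentage points higher from compound 2 to compound 3 (beyond the scatter) and a number 35.7 percentage points higher from compound 1 to compound 3 (beyond the scatter) both beyond the scatter. Compound 4, `N#CC1=C(NC(=O)c2ccccc2O)N(c2ccccc2)C(=O)N2CCCCC(N3CCCC3)C12`, differs from compound 3 in one place: a group of 10 heavy atoms (7 carbon, 1 nitrogen, 2 oxygen; one six-membered aromatic ring of carbon only) in place of a group of 11 heavy atoms (7 carbon, 2 nitrogen, 2 oxygen; one six-membered aromatic ring of carbon only), on a double-bonded ring carbon. The bearing steps are those at this same carbon, a number 23.3 percentage points higher from compound 1 to compound 2 (beyond the scatter) and a number 35.7 percentage points higher from compound 1 to compound 3 (beyond the scatter), where the group carrying a carbonyl and an amino nitrogen gave the lowest number; the incoming group again carries a carbonyl and an amino nitrogen. A downward step is therefore expected, of modest size. Compound 4 is expected to give about 70%, in the range 50% to 88%, which means an expected step of a number 21.7 percentage points lower from compound 3 to compound 4 (beyond the scatter).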

Compound 4, a percentage reported as inhibition, in the whole organism at one dose (the size of the read-out at that dose, not a potency): 65.4%
Compound 4: the middle estimate sits 4.6 percentage points above what was measured; measured number inside the range.
By their numbers in this assay, from the lowest: compounds 1 and 4 (each within the scatter of the next); then compound 2; then compound 3.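

In this assay, the ((2-hydroxyphenyl)carbonyl)amino group on this double-bonded ring carbon gives a number 26.3 percentage points lower from compound 3 to compound 4 (beyond the scatter) and a number 13.9 percentage points lower from compound 2 to compound 4 (beyond the scatter), so an aromatic ring in the entering group does not by itself keep the number high. Against the other group on an amine nitrogen, a number 9.4 percentage points higher from compound 1 to compound 4 (within the scatter), and across these four compounds the two carrying a carbon-nitrogen double bond here stand above the two with an amine nitrogen. Nothing available accounts for these steps. Open, going by these compounds, is what a plain benzoyl group on the amine nitrogen, without the hydroxyl, would give. Also open, on these data alone, is the effect of a methoxy group or an amine in place of the nitro group of the 4-nitrophenyl.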